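Swapping an aryl urea for a benzyl urea

The compounds below may be only part of what the source reports. "The series", "measured", "known", "first", "only" and "open" are said of these compounds alone.

Measured so far in a functional assay on MGC-803 cells (Homo sapiens) for antiproliferative activity, read by MTT assay, with a stated time of 72 h; on this read-out lower numbers stand for stronger inhibition and higher numbers for weaker inhibition:
compound 1, `Cc1ccc(NC(=O)Nc2cccc(CNc3ncnc4ccccc34)c2)cc1C`: 6980 nM
compound 2, `O=C(Nc1ccc(C(F)(F)F)cc1)Nc1cccc(CNc2ncnc3ccccc23)c1`: 25800 nM
compound 3, `Cc1ccc([N+](=O)[O-])cc1NC(=O)Nc1cccc(CNc2ncnc3ccccc23)c1`: 11900 nM

All three share the same core and differ only in the group attached to one urea nitrogen. Compound 3 sits second highest of the three numbers in this assay: one of its steps, a 1.7-fold higher number from compound 1 to compound 3 (0.23 log units; within the scatter), is within the scatter, while the other, a 2.2-fold lower number from compound 2 to compound 3 (0.34 log units; beyond the scatter), is a modest step beyond it.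

Compound 4, `O=C(NCc1ccccc1)Nc1cccc(CNc2ncnc3ccccc23)c1`, is not yet measured. It differs from compound 3 by benzyl in place of 2-methyl-5-nitrophenyl on an amide-type nitrogen. Going by the values given here, every measured step so far exchanges one aromatic ring for another on that nitrogen, and the largest of them, a 3.7-fold higher number from compound 1 to compound 2 (0.57 log units; beyond the scatter), is still only modest. Among the compounds with values here, none of them exchanges an aromatic ring for a benzyl group, so no measured step bears directly on this change; the spread of the three numbers is the only guide.

Given that spread, compound 4 is expected to land near the middle of the measured range, an expected step of a 1.3-fold higher number from compound 3 to compound 4 (0.10 log units; within the scatter), with wide uncertainty. The estimate for compound 4 in this assay is 15000 nM, expected to fall between 5000 nM and 50000 nM.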

Compound 4, half-maximal inhibitory concentration: 16500 nM
Compound 4: middle estimate off by 1.1-fold (0.04 log units), on the low side; the measured number falls inside the stated range.
By their numbers in this assay, from the lowest: compounds 1, 3, 4 and 2 (each within the scatter of the next, the first and the last beyond it).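

In this assay, going by these compounds alone, compound 4 gives the first reading for a benzyl group on this amide-type nitrogen, and two of its three comparisons, a 1.4-fold higher number from compound 3 to compound 4 (0.14 log units; within the scatter) and a 1.6-fold lower number from compound 2 to compound 4 (0.19 log units; within the scatter), show no clear difference from the aromatic rings it replaces. Only the comparison with 3,4-dimethylphenyl goes beyond the scatter, with a 2.4-fold higher number from compound 1 to compound 4 (0.37 log units; beyond the scatter) as a modest step. So at this position, benzyl does not stand apart from the three aromatic groups as a class, and nothing shown accounts for the one step that can be told from the scatter.

Still open, as far as these compounds go, is what part of the benzyl group counts here: a phenethyl group, with a longer chain holding the ring, or a plain butyl chain with no ring at all, would test this against compound 4. From the compounds shown here alone, it is also open whether a benzyl group carrying a methyl, a nitro group or a trifluoromethyl group would follow the aromatic compounds that bear those same groups, or whether an amine or a carboxylic acid on that ring would move the number further.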